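The source may report more compounds than this note shows. Statements on the series, on what has been measured and on what is new or still open speak of the compounds shown alone.

For the measured compounds named here, compound 2 `CNc1cc(C)c(C(N)=O)cn1` is the only compound here with a definite number in an assay on isolated protein for inhibition of Nicotinamide N-methyltransferase (Homo sapiens), read by luminescence, with a stated time of 20 min (on this read-out lower numbers stand for stronger inhibition and higher numbers for weaker inhibition), where compound 2 gives 282 nM. Compound 1 `CCOc1cc(C)c(C(N)=O)cn1` reaches in this assay only a limit, > 10000 nM, which is not a number. Going by the values given here, the single measured step, an at least 35-fold lower number from compound 1 to compound 2 (1.54 log units; beyond the scatter), is therefore known only as a bound because of the limit of > 10000 nM in this assay, at which 1 of the 2 values shown sits. Compound 3 `CNc1cc(C)c(C(N)=S)cn1` differs from compound 2 by a group of 3 heavy atoms (1 carbon, 1 nitrogen, 1 sulfur; no ring) in place of a group of 3 heavy atoms (1 carbon, 1 nitrogen, 1 oxygen; no ring), on an aromatic carbon. No measured step touches this kind of change; the one step shown concerns the methylamino group, not the group that changes here, and so it gives no guide to the size of the new step. With the oxygen of the carbamoyl replaced by sulfur, a weaker number is expected, and the change is expected to give a 5.3-fold higher number from compound 2 to compound 3 (0.73 log units; beyond the scatter). Compound 3 is estimated at 1500 nM in this assay, with a range from 300 nM to 8000 nM.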

Compound 3, half-maximal inhibitory concentration: > 10000 nM
Compound 3: a limit, no number; the forecaster's own chance of this, stated with the estimate: 15%; middle value at least 6.6-fold (0.82 log units) away from the limit.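

The earlier step spoke only to the methylamino group; this result shows that the carbamoyl group on this aromatic carbon also matters in this assay, since exchanging only its oxygen for sulfur gives an at least 35-fold higher number from compound 2 to compound 3 (1.54 log units; beyond the scatter). Compound 3 reaches only a limit, > 10000 nM, which is not a number. The step can therefore be read only as a bound, because the true size is hidden by the limit: the limit of > 10000 nM in this assay, at which 2 of the 3 values shown sit.

Going by these compounds, how far compound 3 really lies from compound 2 stays open, as does whether another group in place of the carbamoyl, such as a carboxylic acid or a nitrile, would give a definite number. Also open, on these data alone, is what a plain amino group or a longer chain such as ethylamino would do in place of the methylamino group.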